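Amino for Fluoro on Two Inactive Oxime Esters

The source may hold more compounds than are shown below. What is called first, only, known or untested is meant among the compounds shown, and "the series" means these compounds.

Compound 1, `O=C(Nc1cccc(C(=O)O/N=C2\CCCc3noc(-c4ccc(F)cc4)c32)c1)c1cccc(F)c1`, in a functional assay on MCF7 cells (Homo sapiens) for antiproliferative activity, read by MTT assay, with a stated time of 72 h (a higher number here means a weaker inhibitor, a lower number a stronger inhibitor), reaches only the limit of the assay, > 25000 nM. Compound 2, `O=C(Nc1cccc(C(=O)O/N=C2\CCCc3noc(-c4cccc(F)c4)c32)c1)c1cccc(F)c1`, in this assay likewise reaches only a limit, > 25000 nM.

Among the compounds with values here, compound 1 therefore stands nowhere on a scale of numbers: only a limit is known for it, and the single further value shown is a limit as well. Within the data shown here, the one change between measured compounds, 3-fluorophenyl in place of 4-fluorophenyl on an aromatic carbon, gives a step that the two limits leave unreadable from compound 1 to compound 2, so its size cannot be read. Both shown values sit at the limit of > 25000 nM in this assay, at which 2 of the 2 values shown sit.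

Compound 3, `Nc1cccc(C(=O)Nc2cccc(C(=O)O/N=C3\CCCc4noc(-c5ccc(F)cc5)c43)c2)c1`, differs from compound 1 by amino in place of fluoro on an aromatic carbon. Among the measured compounds shown here, no measured step touches this position, so nothing in the measured pair bears on it directly. With compound 1 already at the limit, compound 3 is expected to give 30000 nM, within 8000 nM to 120000 nM, most likely again as a limit only. The step that the limit leaves unreadable from compound 1 to compound 3 is accordingly expected to be none beyond the scatter.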

Compound 3, half-maximal inhibitory concentration: > 25000 nM
Compound 3 ended at the assay's limit; the forecaster's own chance of this, stated with the estimate: 75%; the middle value is on the limit's open side.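

The step from compound 1 to compound 3 cannot be read, and no new size can be given, because both compounds end at the same limit, which is not a number: the limit of > 25000 nM in this assay, at which 3 of the 3 values shown sit. The compounds shown leave open whether amino in place of fluoro, or 3-fluorophenyl in place of 4-fluorophenyl, changes the antiproliferative activity at all.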